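Morpholine in Place of Piperidine on the Amide of Compound 3

The source may hold more compounds than are shown below. What is called first, only, known or untested is meant among the compounds shown, and "the series" means these compounds.

Compound 1 `N=C(N)c1cccc(OCC(=O)Nc2ccc(C(=O)N3CCC3)cc2)c1`, compound 2 `N=C(N)c1cccc(OCC(=O)Nc2ccc(C(=O)N3CCCC3)cc2)c1` and compound 3 `N=C(N)c1cccc(OCC(=O)Nc2ccc(C(=O)N3CCCCC3)cc2)c1` share one core and differ only in the ring on the carbonyl carbon. In an assay on isolated protein for inhibition of serine protease 1 (Homo sapiens) (on this read-out higher numbers stand for weaker inhibition and lower numbers for stronger inhibition), compound 1 gives 2050 nM and compound 2 gives 2700 nM. For compound 3 this assay reports only a limit, > 10000 nM. The steps to it were an at least 4.8-fold higher number from compound 1 to compound 3 (0.68 log units; beyond the scatter) and an at least 3.7-fold higher number from compound 2 to compound 3 (0.56 log units; beyond the scatter), whereas a 1.3-fold higher number from compound 1 to compound 2 (0.12 log units; within the scatter). Compound 4 `N=C(N)c1cccc(OCC(=O)Nc2ccc(C(=O)N3CCOCC3)cc2)c1` shows (morpholin-4-yl in place of piperidin-1-yl on a carbonyl carbon). For the measured compounds named here, no measured step swaps one six-membered ring for another, so the ring-size steps fix only the level of compound 3. The expectation for compound 4 is therefore no step beyond the scatter, a number no higher from compound 3 to compound 4 (the limit leaves the size open). Compound 4 is estimated at 10000 nM, with a range from 3000 nM to 30000 nM.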

Compound 4, half-maximal inhibitory concentration: > 10000 nM
Compound 4 ended at the assay's limit; the forecaster's own chance of this, stated with the estimate: 55%; the middle value sits exactly at the limit.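

Morpholin-4-yl on the carbonyl carbon gives an at least 3.7-fold higher number from compound 2 to compound 4 (0.56 log units; beyond the scatter) and an at least 4.8-fold higher number from compound 1 to compound 4 (0.68 log units; beyond the scatter), so in this assay the second six-membered ring also stands apart from the azetidin-1-yl and pyrrolidin-1-yl rings. The hydrogen-bond acceptor that morpholin-4-yl brings does not take compound 4 off the limit of the assay. How compound 3 and compound 4 compare cannot be read because both stand at that limit: the limit of > 10000 nM in this assay, at which 2 of the 4 values shown sit.

Left open is whether piperazin-1-yl or a dimethylamino group on the carbonyl carbon would fall below this limit.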